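Swapping furan-2-yl for pyridin-3-yl on a carbonyl carbon

The source may hold more compounds than are shown below. What is called first, only, known or untested is meant among the compounds shown, and "the series" means these compounds.

Among the measured compounds shown here, in a functional assay on NCI-H460 cells (Homo sapiens) for antiproliferative activity (a lower number here means a stronger inhibitor, a higher number a weaker inhibitor), compound 2 `COc1ccc(S(=O)(=O)Oc2ccccc2NC(=O)c2ccco2)cc1` gives 24 nM, the only exact value so far. Compound 1 `COc1ccc(S(=O)(=O)Oc2ccccc2NC(=O)c2ccc3ncccc3c2)cc1` gives > 10000 nM, which is a limit of the assay and not a number. Compound 3 `COc1ccc(S(=O)(=O)Oc2ccccc2NC(=O)c2cccnc2)cc1` has pyridin-3-yl in place of furan-2-yl on a carbonyl carbon. For the measured compounds named here, only one measured step changes this same place, and it is large: an at least 410-fold lower number from compound 1 to compound 2 (2.61 log units; beyond the scatter). With that single step as a thin guide, moving away from furan-2-yl is expected to raise the number. The estimated change is a 17-fold higher number from compound 2 to compound 3 (1.22 log units; beyond the scatter). For compound 3, the expected value is 400 nM, within an estimated range of 40 nM to 6000 nM.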

Compound 3, half-maximal inhibitory concentration: > 6000 nM
Compound 3: no number, only a limit; the forecaster's own chance of this, stated with the estimate: 20%; middle value at least 15-fold (1.17 log units) from the limit.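

In this assay the smaller pyridin-3-yl on the carbonyl carbon loses activity just as quinolin-6-yl does (an at least 250-fold higher number from compound 2 to compound 3 (2.39 log units; beyond the scatter)), so of the three groups shown, only furan-2-yl gives an exact value. Compound 3 gives > 6000 nM as a limit of the assay and not a number. The step from compound 1 to compound 3 cannot be read, as both values are limits.

On these data alone, whether thiophen-2-yl or phenyl would stay close to compound 2 remains open. So does the activity of a short alkyl chain in this place.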